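This account rests on a few compounds, and the source may have more. Where it says the series, first, only, none or still open, it means among the compounds named here.

Measured compounds:
- compound 2 `Nc1cc(N)c2nc(-c3ccccc3)c(NCc3ccc(Cl)c(Cl)c3)nc2c1` gives 24000 nM in a functional assay on SN12C cells (Homo sapiens) for inhibition, read by sulforhodamine B assay, with a stated time of 48 h; on this read-out higher numbers stand for weaker inhibition of growth and lower numbers for stronger inhibition of growth.
- compound 1 `CCOC(=O)[C@H](CCC(=O)O)NC(=O)c1ccc(CNc2nc3cc(N)cc(N)c3nc2-c2ccccc2)cc1` gives only a limit of the assay, < 100000 nM, in this assay.

Among the measured compounds shown here, compound 2 thus stands as the only actual number in this assay; the other entry is a limit. For the measured compounds named here, no step between two measured compounds that differ in one place is available in this set, so no measured change of this kind can be leaned on.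

Compound 3 `COc1ccc(CNc2nc3cc(N)cc(N)c3nc2-c2ccccc2)cc1` is not yet measured. It differs from compound 2 by 4-methoxyphenyl in place of 3,4-dichlorophenyl on a saturated chain carbon bound to a nitrogen on an aromatic ring. With no measured step of this kind to draw on, the shown data set neither a direction nor a size for the change; the expectation rests on compound 2 alone, which gives 24000 nM in this assay. The step of a 1.7-fold higher number from compound 2 to compound 3 (0.22 log units; within the scatter) is expected to stay within the usual scatter, with no direction implied. The estimate for compound 3 is 40000 nM, with a range from 10000 nM to 100000 nM. Since one of the two shown values sits at the limit of < 100000 nM in this assay, at which 1 of the 2 values shown sits, there is a real chance that compound 3 is reported only as a limit as well.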

Compound 3, concentration for total growth inhibition: 34700 nM
Compound 3: the middle estimate sits 1.2-fold (0.06 log units) above what was measured; the measured number falls inside the stated range.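

In this assay, 4-methoxyphenyl in place of 3,4-dichlorophenyl on a saturated chain carbon bound to a nitrogen on an aromatic ring gives a 1.4-fold higher number from compound 2 to compound 3 (0.16 log units; within the scatter). Among the compounds shown here, this is the first measured step at this place, and it lies within the scatter, so the two groups cannot be told apart on this read-out, although they differ in their atoms (two chlorines against one oxygen) and in their hydrogen-bond acceptor count (none against one). Compound 3 also returns an actual number rather than a limit, so compound 2 no longer stands alone as a measured value, and this single change at this place leaves the read-out where it was.

As far as these compounds go, whether a nitrile or trifluoromethyl on the phenyl ring, or a longer chain in place of the single saturated chain carbon, would move the number beyond the scatter remains open, and one step cannot show whether this place is insensitive in general. Any change toward weaker inhibition of growth may also be hard to read as a number, as the upper end of this read-out is already reached in the set: the limit of < 100000 nM in this assay, at which 1 of the 3 values shown sits.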